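A few compounds are considered here, and "the series" means these few. Any claim that something is new, unique, unknown or untested is made for them only; others in the source may bear on it.

Working notes on the series in a functional assay on K562 cells (Homo sapiens) for cytotoxicity, read by MTT assay; a higher number here means a weaker inhibitor, a lower number a stronger inhibitor. Compound 1 `C#CCOc1cc(/C=C/C(=O)c2ccc(OC)c3c2OC(C)(C)C=C3)ccc1OC` gives > 10000 nM, and this is a limit of the assay, not a number. For the measured compounds named here, compound 2 `CCCCC(=O)Oc1cc(/C=C/C(=O)c2ccc(OC)c3c2OC(C)(C)C=C3)ccc1OC` gives 240 nM, the only actual number so far. The next analogue is compound 3 `COc1cccc(C(=O)Oc2cc(/C=C/C(=O)c3ccc(OC)c4c3OC(C)(C)C=C4)ccc2OC)c1`, and the change is 3-methoxyphenyl in place of butyl on a carbonyl carbon. In words, 3-methoxyphenyl stands in place of butyl on a carbonyl carbon, so butylcarbonyl becomes (3-methoxyphenyl)carbonyl.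

Going by the values given here, one measured step bears on this: an at least 41-fold lower number from compound 1 to compound 2 (1.61 log units; beyond the scatter). That step is large and beyond the scatter, but its size rests on a limit, and it exchanged propargyl for butylcarbonyl on an oxygen on an aromatic ring. It shows that the number responds strongly to the group on that oxygen, but it does not test the group on the carbonyl carbon. A moderate step towards a higher number is therefore expected, with low confidence in its size and direction. The expected change is a 2.9-fold higher number from compound 2 to compound 3 (0.46 log units; beyond the scatter). For compound 3 the estimated value is 700 nM, with an expected range from 150 nM to 4000 nM.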

Compound 3, half-maximal inhibitory concentration: 790 nM
For compound 3 the middle estimate is 1.1-fold (0.05 log units) below the measured one, and the stated range covers the measured number.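

In this assay, for the compounds shown here, the group on the carbonyl carbon is tested directly for the first time, and the step of a 3.3-fold higher number from compound 2 to compound 3 (0.52 log units; beyond the scatter) shows that the number responds to this group as well as to the group on the aromatic oxygen, though only modestly next to the earlier step. Exchanging butyl for 3-methoxyphenyl, with its six-membered aromatic ring and added hydrogen-bond acceptor, costs some strength without a collapse, and the step of an at least 12-fold lower number from compound 1 to compound 3 (1.10 log units; beyond the scatter) keeps the aryl compound well clear of the propargyl compound, so among these three compounds both carbonyl compounds have the lower numbers. Compound 1 carries a limit and not a number, and both steps from it are bounds and not sizes because of that limit: the limit of > 10000 nM in this assay, at which 1 of the 3 values shown sits.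

Going by these compounds, whether the loss from butyl to 3-methoxyphenyl belongs to the ring itself or to the methoxy group on it stays open, and plain phenyl on the carbonyl carbon would separate the two. Also open, on these data alone, is how a longer chain, a shorter chain such as methyl, or an amine on that carbonyl carbon would compare with butyl.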